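The source may report more compounds than this note shows. Statements on the series, on what has been measured and on what is new or still open speak of the compounds shown alone.

Compound 1 `Cc1ccc(S(=O)(=O)N/C(=N\O)Nc2ccc(Cl)cc2)cc1`: 49 ug/mL
Compound 2 `N#Cc1c(Cl)cccc1Oc1ccc(S(=O)(=O)N/C(=N\O)Nc2ccc(Cl)cc2)cc1`: > 300 ug/mL
Compound 3 `CCCCOc1ccc(S(=O)(=O)N/C(=N\O)Nc2ccc(Cl)cc2)cc1`: 63 ug/mL

In a functional assay on HepG2 cells (Homo sapiens) for cytotoxicity (on this read-out higher numbers stand for weaker inhibition and lower numbers for stronger inhibition), compound 1 gives 49 ug/mL and compound 3 gives 63 ug/mL, two values that lie within the scatter of each other. Compound 2 gives only a limit, > 300 ug/mL, and not a number.

The next compound, compound 4 `Cc1ccc(S(=O)(=O)N/C(=N\O)Nc2ccc(Cl)c(Cl)c2)cc1`, keeps the core of compound 1 and carries a chloro in place of hydrogen on an aromatic carbon, ortho to a chloro group and meta to a large group (chloro in place of hydrogen on an aromatic carbon). Among the measured compounds shown here, all three measured compounds share the same group at this place, so no measured step tests the change directly. The measured steps all lie at the other end of the molecule and bear on it only loosely. The butoxy swap gave a 1.3-fold higher number from compound 1 to compound 3 (0.11 log units; within the scatter), while the 3-chloro-2-cyanophenoxy swap gave an at least 6.1-fold higher number from compound 1 to compound 2 (0.78 log units; beyond the scatter), a step that rests on a limit. Going from compound 2 to the butoxy group gave an at least 4.7-fold lower number from compound 2 to compound 3 (0.67 log units; beyond the scatter). The swap here is far smaller than the 3-chloro-2-cyanophenoxy one, so no step beyond the scatter is expected, with a slight lowering the likelier direction. The expected change is a 1.4-fold lower number from compound 1 to compound 4 (0.15 log units; within the scatter). For compound 4 the estimated value is 35 ug/mL, with an expected range from 14 ug/mL to 90 ug/mL.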

Compound 4, half-maximal inhibitory concentration: 72 ug/mL
Beside the measured number, compound 4's estimate is 2.1-fold (0.31 log units) below it; the measured number falls inside the stated range.
By their numbers in this assay, from the lowest: compounds 1, 3 and 4 (each within the scatter of the next). At a limit, above all of these: compound 2.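

Among the compounds shown here, this is the first change at this position, as compounds 1, 2 and 3 differ only at the other end of the molecule. In this assay, chloro in place of hydrogen on an aromatic carbon, ortho to a chloro group, gives a 1.5-fold higher number from compound 1 to compound 4 (0.17 log units; within the scatter), so this position accepts one added chlorine with no step beyond the usual variation between repeated measurements. Nothing shown here explains why this added atom leaves the read-out within the scatter.

A single substituent says little about the position as a whole, and an amine, a methoxy group or a carboxylic acid on this same aromatic carbon might give a quite different number in this assay. From the compounds shown here alone, it also remains open whether the second chloro would behave the same way in a compound carrying butoxy or 3-chloro-2-cyanophenoxy at the other end, where the first of these groups stays within the scatter of methyl and the second moves the read-out beyond it.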